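Pyrazolyl-indazole series: inverting the pyrrolidine stereocentre

The compounds below may be only part of what the source reports. "The series", "measured", "known", "first", "only" and "open" are said of these compounds alone.

Measured so far:
- compound 1, `Cn1cc(-c2nn(C)c3cc(N)ccc23)cn1`: > 384000 nM
- compound 2, `Cn1cc(-c2n[nH]c3ccc(N[C@@H]4CCNC4)cc23)cn1`: 37000 nM
- compound 3, `Cn1cc(-c2n[nH]c3cc(Cl)c(Br)cc23)cn1`: 850 nM

All three were run in an assay on isolated protein for inhibition of tyrosine-protein kinase receptor UFO (Homo sapiens), with a stated time of 1.5 h; a higher number here means a weaker inhibitor, a lower number a stronger inhibitor. Compound 1 gives only > 384000 nM, which is a limit of the assay and not a number. Of the two real numbers, compound 2 holds the higher one in this assay; its nearest neighbour is compound 3, whose number lies lower by a gap well beyond the scatter. Within the data shown here, no pair of measured compounds differs in a single place, so no measured step is available to lean on.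

Compound 4, `Cn1cc(-c2n[nH]c3ccc(N[C@H]4CCNC4)cc23)cn1`, is the next candidate for this assay. Relative to compound 2 the difference is: the two compounds have the same atoms and bonds and differ only in configuration as drawn: 1 of 1 stereo elements differ; a stereocentre at a saturated ring carbon is drawn R in compound 2 and S in compound 4. Among the measured compounds shown here, nothing among the measured compounds shows what inverting this centre does. An inverted stereocentre can move the number either way, and with no evidence for a direction the step is expected to be a 1.2-fold lower number from compound 2 to compound 4 (0.09 log units; within the scatter), that is, no change beyond the scatter, with the range kept wide enough to admit a shift beyond the scatter on either side. Compound 4 is accordingly estimated at 30000 nM, between 7000 nM and 130000 nM.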

Compound 4, half-maximal inhibitory concentration: 239000 nM
Compound 4: middle estimate off by 8.0-fold (0.90 log units), on the low side; the measured number lies above the stated range.
By their numbers in this assay, from the lowest: compound 3; then compound 2; then compound 4. At a limit, above all of these: compound 1.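

In this assay, the configuration at the saturated ring carbon of the pyrrolidine turns out not to be neutral: drawing this stereocentre S instead of R gives a 6.5-fold higher number from compound 2 to compound 4 (0.81 log units; beyond the scatter). The shift can be assigned to the configuration alone because nothing else separates this pair: the fact that compounds 2 and 4 differ only in the configuration as drawn. Among these compounds, this is the first single-place step, so the R form of compound 2 is now the better-supported configuration for this side chain, although that reading rests on one pair and one assay.

The compounds shown leave open whether the preference for R persists when the pyrrolidine carries a further group, such as an acetyl group or a longer chain, or whether any difference survives when an open-chain amine replaces the ring. Among the compounds shown here, they also leave open how this amino side chain compares with the chlorine and bromine of compound 3, as that pair differs in more than one place and offers no clean step.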